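This account rests on a few compounds, and the source may have more. Where it says the series, first, only, none or still open, it means among the compounds named here.

In a physicochemical assay for solubility, at pH 7 (a lower number here means a less soluble compound, a higher number a more soluble compound), compound 2 `CN1CCC(C(=O)N2Cc3c(NC(=O)c4cccs4)n[nH]c3C2(C)C)CC1` gives 155000 nM, the higher of the two actual numbers available. The other number comes from compound 3 `CC1(C)c2[nH]nc(NC(=O)c3ccc(F)cc3)c2CN1C(=O)N1CCN(c2ccccc2)CC1`, at 55000 nM, and the gap between them lies beyond the scatter. Compound 1 `CN1CCC(C(=O)N2Cc3c(NC(=O)c4ccsc4)n[nH]c3C2(C)C)CC1` reads > 225000 nM, which is a limit of the assay and not a number.

Compound 4 `CN1CCC(C(=O)N2Cc3c(NC(=O)c4cccc(F)c4)n[nH]c3C2(C)C)CC1` has 3-fluorophenyl in place of thiophen-2-yl on a carbonyl carbon. For the measured compounds named here, the only measured step at that carbonyl carbon is an at least 1.4-fold lower number from compound 1 to compound 2 (0.16 log units; that floor lies within the scatter), with thiophen-2-yl in place of thiophen-3-yl. That step starts from a limit and exchanges one thiophene attachment for another, so it offers only weak guidance for the new change. Compound 3 differs from compound 2 in more than one place, but the value of compound 3 at 55000 nM leads to a cautious expectation of a lower number in this assay. The estimated step is a 1.6-fold lower number from compound 2 to compound 4 (0.21 log units; within the scatter), which is expected to remain small. Compound 4 is estimated at 95000 nM, with an expected range of 40000 nM to 200000 nM.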

Compound 4, solubility: > 225000 nM
Compound 4 gave a limit, no number; the forecaster's own chance of this, stated with the estimate: 12%; middle value at least 2.3-fold (0.37 log units) from the limit.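

In this assay, going by these compounds, 3-fluorophenyl in place of thiophen-2-yl on a carbonyl carbon gives an at least 1.4-fold higher number from compound 2 to compound 4 (0.16 log units; that floor lies within the scatter), so the true size of this change remains unknown. Compound 4 reads > 225000 nM, which is a limit of the assay and not a number. Among the compounds sharing this core, only thiophene groups had been seen at this carbonyl carbon, and this result shows that a six-membered aromatic ring of carbon only, bearing fluorine, can also reach the same limit as compound 1: the limit of > 225000 nM in this assay, at which 2 of the 4 values shown sit.

On these data alone, the step between compound 1 and compound 4 cannot be read, so their order remains unknown. As far as these compounds go, it also remains open whether an amine or a longer chain on this carbonyl carbon would give a reading that falls below the limit.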